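Bromo to hydrogen on compound 2: expected effect

The compounds below may be only part of what the source reports. "The series", "measured", "known", "first", "only" and "open" are said of these compounds alone.

Compound 1 `O=C(CSc1nnc(-c2ccncc2)n1-c1ccccc1)N/N=C/c1ccc(F)cc1` in a functional assay on HepG2 cells (Homo sapiens) for inhibition, read by MTT assay, with a stated time of 48 h (on this read-out lower numbers stand for stronger inhibition and higher numbers for weaker inhibition), gives 9330 nM. Compound 2 `O=C(CSc1nnc(-c2ccncc2)n1-c1ccccc1)N/N=C/c1cc(Br)ccc1O` gives 4390 nM in this assay, which is a 2.1-fold lower number from compound 1 to compound 2 (0.33 log units; beyond the scatter). Among these two numbers compound 2 stands lowest, with compound 1 as its only neighbour. Compound 3 `O=C(CSc1nnc(-c2ccncc2)n1-c1ccccc1)N/N=C/c1ccccc1O` differs from compound 2 by hydrogen in place of bromo on an aromatic carbon. Among the compounds with values here, only one measured step is at hand, and it exchanges the whole aryl group rather than the bromo alone, so it bears on the new change only indirectly; the bromo was part of what entered in that step, and the step itself was modest. A step of similar or smaller size is therefore expected in this assay, more likely toward a higher number, and it may well stay within the scatter. For compound 3 a value of 7000 nM is expected, with a range from 3000 nM to 16000 nM. This amounts to an expected 1.6-fold higher number from compound 2 to compound 3 (0.20 log units; within the scatter).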

Compound 3, half-maximal inhibitory concentration: 11300 nM
Beside the measured number, compound 3's estimate is 1.6-fold (0.21 log units) below it, within the range that was stated.
By their numbers in this assay, from the lowest: compound 2; then compounds 1 and 3 (each within the scatter of the next).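

In this assay, the bromo on this aromatic carbon, para to the hydroxy group, accounts for a readable step: its replacement by hydrogen gives a 2.6-fold higher number from compound 2 to compound 3 (0.41 log units; beyond the scatter). The hydroxy group without the bromo shows no separation from the 4-fluorophenyl compound, with 2-hydroxyphenyl in place of 4-fluorophenyl giving a 1.2-fold higher number from compound 1 to compound 3 (0.08 log units; within the scatter), so within these three compounds the lower number of compound 2 appears only when bromo and hydroxy are both present. No measured information on the cause of this step is available.

As far as these compounds go, whether the step is specific to bromo or would also appear with another group on this carbon, such as chloro, methoxy or an amine, remains open. Also open, from the compounds shown here alone, is whether bromo gives a similar step on an aryl group that lacks the hydroxy group.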